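Swapping cyclohexyl for fluorophenyl on the shared core

This account rests on a few compounds, and the source may have more. Where it says the series, first, only, none or still open, it means among the compounds named here.

Of the compounds shown here, three have been tested in a functional assay on MDA-MB-231 cells (Homo sapiens) for antiproliferative activity, read by sulforhodamine B assay; a higher number here means a weaker inhibitor of growth, a lower number a stronger inhibitor of growth. Compound 1 `CC(C)C1CC(=O)c2s/c(=N/c3ccccc3)oc2C1` gives 2480 nM, compound 2 `CC(C)C1CC(=O)c2s/c(=N/C3CCCCC3)oc2C1` gives 5900 nM, and compound 3 `CC1(C)CC(=O)c2s/c(=N/c3ccc(F)cc3)oc2C1` gives 3200 nM. Among the compounds with values here, on these numbers compound 2 stands at the highest value of the three; its gap to compound 3 lies within the scatter, while its gap to compound 1 lies beyond it, as the one single-point step in the set shows: a 2.4-fold higher number from compound 1 to compound 2 (0.38 log units; beyond the scatter).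

The unmeasured compound 4 `CC(C)C1CC(=O)c2s/c(=N/c3ccc(F)cc3)oc2C1` differs from compound 2 in one place: 4-fluorophenyl in place of cyclohexyl on a double-bonded nitrogen. Within the data shown here, the step that bears on this change is the one from compound 1 to compound 2, in which the reverse exchange, cyclohexyl for phenyl, raised the number by a modest amount beyond the scatter. Compound 3 carries the same 4-fluorophenyl group on a closely related core and gives a value near that of compound 1.

Compound 4 is therefore expected to move back down in this assay by a modest step beyond the scatter, a 2.2-fold lower number from compound 2 to compound 4 (0.34 log units; beyond the scatter). The estimate for compound 4 is 2700 nM, with a range from 1200 nM to 6000 nM.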

Compound 4, concentration for 50% growth inhibition: 2690 nM
For compound 4 the middle estimate is 1.0-fold (0.00 log units) above the measured one, and the stated range covers the measured number.
By their numbers in this assay, from the lowest: compounds 1, 4, 3 and 2 (each within the scatter of the next, the first and the last beyond it).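

On the core that carries the isopropyl group, the exchange on the double-bonded nitrogen can now be read in this assay in a second pair, and 4-fluorophenyl in place of cyclohexyl gives (a 2.2-fold lower number from compound 2 to compound 4 (0.34 log units; beyond the scatter)). Fluoro in place of hydrogen on an aromatic carbon gives (a 1.1-fold higher number from compound 1 to compound 4 (0.04 log units; within the scatter)), so the assay does not separate the phenyl and 4-fluorophenyl groups at this place, while each of the two compounds that carry them stands apart from the cyclohexyl compound 2 by a modest step beyond the scatter. Nothing offered here accounts for why the six-membered carbon ring on the nitrogen does better as an aromatic ring than as a non-aromatic one.

The compounds shown leave open whether other groups on that aromatic ring, such as a chlorine or a methoxy group, would also stay within the scatter of compound 1, and whether a straight butyl chain or a pyridine ring on the double-bonded nitrogen would behave like cyclohexyl or like phenyl. They also leave open whether the same exchange holds on the core of compound 3, where a cyclohexyl partner does not appear among them.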